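A few compounds are considered here, and "the series" means these few. Any claim that something is new, unique, unknown or untested is made for them only; others in the source may bear on it.

Measured compounds:
- compound 1 `COc1ccccc1-c1nnc(-c2ccc(C(=O)N/N=C/c3c(O)cc(O)cc3O)cc2)o1`: in an ADME assay on THP-1 cells (Homo sapiens) for cytotoxicity (on this read-out higher numbers stand for weaker inhibition and lower numbers for stronger inhibition), compound 1 gives 12400 nM
- compound 2 `COc1ccccc1-c1nnc(-c2ccc(C(=O)N/N=C/c3cccc(O)c3O)cc2)o1`: compound 2 gives 102000 nM
- compound 3 `COc1ccc(/C=N/NC(=O)c2ccc(-c3nnc(-c4ccccc4OC)o3)cc2)c(O)c1`: compound 3 gives 308000 nM

Compound 2 stands between the other two on these numbers: an 8.2-fold higher number from compound 1 to compound 2 (0.92 log units; beyond the scatter) and a 3.0-fold higher number from compound 2 to compound 3 (0.48 log units; beyond the scatter), both beyond the scatter. Compound 4 `COc1ccccc1-c1nnc(-c2ccc(C(=O)N/N=C/c3ccc(O)cc3)cc2)o1` is not yet measured; it differs from compound 2 by 4-hydroxyphenyl in place of 2,3-dihydroxyphenyl on a carbon with a double bond to nitrogen. All three measured steps concern the same carbon with a double bond to nitrogen, and each one that leaves that ring with fewer hydroxyl groups goes to a higher number: an 8.2-fold higher number from compound 1 to compound 2 (0.92 log units; beyond the scatter), a 25-fold higher number from compound 1 to compound 3 (1.40 log units; beyond the scatter), a 3.0-fold higher number from compound 2 to compound 3 (0.48 log units; beyond the scatter). Compound 4 carries one hydroxyl group fewer than compound 2, so a modest step to a higher number is expected, a 2.5-fold higher number from compound 2 to compound 4 (0.39 log units; beyond the scatter). Compound 4 is therefore estimated at 250000 nM, with a range from 80000 nM to 800000 nM.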

Compound 4, half-maximal inhibitory concentration: 261000 nM
Compound 4: middle estimate off by 1.0-fold (0.02 log units), on the low side; the range from low to high includes it.
By their numbers in this assay, from the lowest: compound 1; then compound 2; then compounds 4 and 3 (each within the scatter of the next).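

On the carbon with a double bond to nitrogen, 4-hydroxyphenyl continues the hydroxyl trend in this assay, with a 2.6-fold higher number from compound 2 to compound 4 (0.41 log units; beyond the scatter) and a 21-fold higher number from compound 1 to compound 4 (1.32 log units; beyond the scatter). The trend does not separate the last pair, with a 1.2-fold lower number from compound 3 to compound 4 (0.07 log units; within the scatter), so only 2,4,6-trihydroxyphenyl and 2,3-dihydroxyphenyl give clearly lower numbers. Nothing at hand explains these steps.

Open, as far as these compounds go, is where an unsubstituted phenyl would fall. Also open, from the compounds shown here alone, is whether an amine or a carboxylic acid on this ring could take the place of the hydroxyl groups.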